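The compounds below may be only part of what the source reports. "The series", "measured", "known", "first", "only" and "open" are said of these compounds alone.

In a functional assay on NCI-H460 cells (Homo sapiens) for cytotoxicity, read by MTT assay (on this read-out higher numbers stand for weaker inhibition and lower numbers for stronger inhibition), three compounds built on a shared core have so far been measured, and none of them has given a number. Compound 1 `Cc1cccc(Nc2nc(C)c(C(=O)/C=C/c3ccccc3Cl)s2)c1` reaches only a limit of the assay, > 25000 nM. Compound 2 `Cc1ccc(Nc2nc(C)c(C(=O)/C=C/c3ccc(Cl)cc3)s2)cc1` likewise reaches only a limit, > 25000 nM. Compound 3 `COc1cc(/C=C/C(=O)c2sc(Nc3ccc(Cl)c(Cl)c3)nc2C)cc(OC)c1OC` also reaches only a limit, > 25000 nM. Among the compounds with values here, all three results therefore sit at one point, (the limit of > 25000 nM in this assay, at which 3 of the 3 values shown sit), so no step between measured compounds can be counted, and compound 3 stands with the other two at that limit rather than anywhere on a scale.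

Compound 4 `COc1cc(/C=C/C(=O)c2sc(Nc3cccc(C)c3)nc2C)cc(OC)c1OC` has not yet been measured. It differs from compound 3 in one place: 3-methylphenyl in place of 3,4-dichlorophenyl on a nitrogen on an aromatic ring. Within the data shown here, compounds 1 and 2 each gave only a limit as well, so among the three results nothing has yet moved the read-out into the measurable range, and there is no measured step that shows what a change on this nitrogen does. With nothing to lean on, the step expected from compound 3 to compound 4, a step that the limit leaves unreadable from compound 3 to compound 4, is none beyond the scatter, and the expected outcome is again a limit. Compound 4 is therefore estimated at 30000 nM, within a range from 8000 nM to 100000 nM, with the most likely report being that the assay limit is reached once more.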

Compound 4, half-maximal inhibitory concentration: 19800 nM
The estimate for compound 4 lay 1.5-fold (0.18 log units) above the measured number, and the stated range covers the measured number.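

In this assay, placing 3-methylphenyl in place of 3,4-dichlorophenyl on the nitrogen gives an at least 1.2-fold lower number from compound 3 to compound 4 (0.10 log units; that floor lies within the scatter), and compound 4 is the only one of the four compounds shown to give a number rather than a limit, 19800 nM. Compound 3 gives only a limit, > 25000 nM, so the step is a floor and not a measured size: the change may be larger than printed, but the data establish no change beyond the scatter. What compound 4 adds is a single reading on the scale for this substitution on the nitrogen, with no second number to set it against: the limit of > 25000 nM in this assay, at which 3 of the 4 values shown sit.

On these data alone, one number cannot show a trend at this position, and it remains open whether the methyl group, the loss of the two chlorine atoms or both matter to the read-out in this assay. Also open, as far as these compounds go, is how the read-out would respond if a longer chain replaced that methyl group, or if an amine or a carboxylic acid stood on the same aromatic ring.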